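Series notes: octyl to aryl on the ring nitrogen

A few compounds are considered here, and "the series" means these few. Any claim that something is new, unique, unknown or untested is made for them only; others in the source may bear on it.

Compound 1 `CCCCCCCCn1cc(COC2(C(F)(F)F)Oc3ccccc3C=C2C(=O)OCC)nn1` stands at the limit of a functional assay on HeLa cells (Homo sapiens) for inhibition, read by MTT assay, with a stated time of 24 h; on this read-out lower numbers stand for stronger inhibition and higher numbers for weaker inhibition: in this assay compound 1 gives > 150000 nM, which is a limit rather than a number. Two of the three values shown share that limit (the limit of > 150000 nM in this assay, at which 2 of the 3 values shown sit). For the measured compounds named here, compound 2 `Cc1ccc(-c2cc(COC3(C(F)(F)F)Oc4ccccc4C=C3C(=O)O)on2)cc1` is the only member with a number; in this assay compound 2 gives 33400 nM. Compound 3 `O=C(O)C1=Cc2ccccc2OC1(OCc1cc(-c2ccc([N+](=O)[O-])cc2)no1)C(F)(F)F` returns a limit: in this assay compound 3 gives > 150000 nM. Going by the values given here, the one measured step, an at least 4.4-fold higher number from compound 2 to compound 3 (0.65 log units; beyond the scatter), runs from a number to a limit.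

Compound 4 `CCOC(=O)C1=Cc2ccccc2OC1(OCc1cn(-c2cccc(C(F)(F)F)c2)nn1)C(F)(F)F` differs from compound 1 by 3-(trifluoromethyl)phenyl in place of octyl on an aromatic nitrogen. Among the compounds with values here, no measured step alters the group on the aromatic nitrogen, and none starts from a limit; the step of an at least 4.4-fold higher number from compound 2 to compound 3 (0.65 log units; beyond the scatter) swaps a substituent on an aromatic carbon in a different part of the molecule and shows only that such swaps can carry a value to the limit. Compound 1 itself begins at the limit, so no weaker number can be read off, and nothing in the series points to a gain. Compound 4 is therefore expected to stay at or near the limit, with a step of an at least 1.1-fold lower number from compound 1 to compound 4 (0.06 log units; that floor lies within the scatter). The estimate for compound 4 in this assay is 130000 nM, in a range from 40000 nM to 400000 nM.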

Compound 4, half-maximal inhibitory concentration: > 150000 nM
Compound 4: no number, only a limit (the forecaster's own chance of this, stated with the estimate: 55%); at least 1.1-fold (0.06 log units) between middle value and limit.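

In this assay, for the compounds shown here, compound 4 gives > 150000 nM, a limit and not a number, so no step from compound 1, which also stands at a limit, can be read: the limit of > 150000 nM in this assay, at which 3 of the 4 values shown sit. The compounds shown leave open whether octyl or 3-(trifluoromethyl)phenyl on the aromatic nitrogen gives the stronger inhibition.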